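Swapping trifluoromethoxy for a hydroxyl on the side ring

The compounds below may be only part of what the source reports. "The series", "measured", "known", "first", "only" and "open" are said of these compounds alone.

In a physicochemical assay for solubility, read by spectrophotometry, in phosphate buffer, with a stated time of 18 h, at pH 7.4 (on this read-out lower numbers stand for lower solubility and higher numbers for higher solubility), compound 1 `CCc1ccc(-c2nc3c(c(C)nn3-c3ccccc3)c(-c3ccccc3O)c2C#N)cc1` gives 3100 nM, and compound 2 `CCc1ccc(-c2nc3c(c(C)nn3-c3ccccc3)c(-c3ccccc3OC(F)(F)F)c2C#N)cc1` gives 9900 nM. Going by the values given here, compound 2 thus holds the higher of the two numbers so far. Compound 3 `CCc1ccc(-c2nc3c(c(C)nn3-c3ccccc3)c(-c3cccc(O)c3)c2C#N)cc1` has not yet been measured. It differs from compound 2 by one swap: 3-hydroxyphenyl in place of 2-(trifluoromethoxy)phenyl on an aromatic carbon. In words, 3-hydroxyphenyl takes the place of 2-(trifluoromethoxy)phenyl on an aromatic carbon, opposite the ring nitrogen.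

Among the compounds with values here, only one measured step bears on this swap, and it is modest: a 3.2-fold higher number from compound 1 to compound 2 (0.50 log units; beyond the scatter). In that step, trifluoromethyl replaced the hydrogen on an oxygen on an aromatic ring. Compound 3 goes the other way and again carries a hydroxyl, though compound 1 does not have the 3-hydroxyphenyl group, so the comparison is imperfect. A step of similar size towards lower numbers is therefore expected in this assay, and this single precedent leaves the range wide. The expected step is a 3.3-fold lower number from compound 2 to compound 3 (0.52 log units; beyond the scatter). For compound 3 the estimate is 3000 nM, with an expected range of 1000 nM to 8000 nM.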

Compound 3, solubility: 18000 nM
The estimate for compound 3 lay 6.0-fold (0.78 log units) below the measured number; the measured number lies above the stated range.
By their numbers in this assay, from the lowest: compound 1; then compounds 2 and 3 (each within the scatter of the next).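

The hydroxyl on the side ring does not fix the number by itself: going from 2-hydroxyphenyl to 3-hydroxyphenyl gives a 5.8-fold higher number from compound 1 to compound 3 (0.76 log units; beyond the scatter) in this assay, so the place of this group on the ring matters to this read-out. The swap of 2-(trifluoromethoxy)phenyl for 3-hydroxyphenyl gives a 1.8-fold higher number from compound 2 to compound 3 (0.26 log units; within the scatter), so these two groups cannot be told apart in this assay, although they differ in heavy atoms and in hydrogen-bond donors. The earlier step from compound 1 to compound 2 therefore cannot be read as a rule that a hydroxyl on this ring goes with a lower number, since compound 1 and compound 3 both carry one and only compound 1 stands lowest of the three.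

Nothing available on these compounds explains why the place of the hydroxyl counts. Also open, as far as these compounds go, is what a trifluoromethoxy group would give where compound 3 carries its hydroxyl, which would separate the effect of the group from that of its place, and what an amine or a carboxylic acid on this side ring would give.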